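Chloro on the Phenyl Ring of a Tetrazole-Benzimidazole Pair

The source may hold more compounds than are shown below. What is called first, only, known or untested is meant among the compounds shown, and "the series" means these compounds.

Compound 1 `Clc1ccccc1-c1nnn(CCCn2cnc3c(Br)c(Br)c(Br)c(Br)c32)n1` gives 96% in a functional assay on CCRF-CEM cells (Homo sapiens) for cytotoxicity, read by MTT assay, with a stated time of 24 h, tested at 25 uM; on this read-out higher numbers stand for a weaker effect at the one concentration tested and lower numbers for a stronger effect.
Compound 2 `Brc1c(Br)c(Br)c2c(ncn2CCCn2nnnc2-c2ccccc2)c1Br` gives 4% in this assay.

Compound 2 stands lowest of the two numbers; its nearest neighbour, compound 1, lies far higher, beyond the scatter. Compound 3 `Clc1ccccc1-c1nnnn1CCCn1cnc2c(Br)c(Br)c(Br)c(Br)c21` has not yet been measured. It differs from compound 2 by chloro in place of hydrogen on an aromatic carbon. Compound 1 also carries a 2-chlorophenyl group and gives the high reading, so for compound 3 a step upward is expected, estimated as a number 51 percentage points higher from compound 2 to compound 3 (beyond the scatter). Compound 3 is estimated to give 55%, with a range from 10% to 95%.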

Compound 3, a percentage reported as inhibition, at one concentration (the size of the read-out at that concentration, not a potency): 1%
Compound 3: the middle estimate sits 54 percentage points above what was measured; the measured number lies below the stated range.
By their numbers in this assay, from the lowest: compounds 3 and 2 (each within the scatter of the next); then compound 1.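

Chloro in place of hydrogen on this aromatic carbon leaves the reading in this assay within the scatter, with a number 3 percentage points lower from compound 2 to compound 3 (within the scatter). The 2-chlorophenyl group alone therefore does not bring the high reading: compound 3 carries it and gives 1%, whereas compound 1 gives 96%. No measurement at hand offers an explanation for this result. As far as these compounds go, it remains open whether an amine or a methoxy group on this carbon would read like hydrogen and chloro, and whether a longer chain in the linker would keep the reading as low.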